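Notes on the step from compound 3 to compound 4

The compounds below may be only part of what the source reports. "The series", "measured", "known", "first", "only" and "open" are said of these compounds alone.

Measured so far in a physicochemical assay for lipophilicity, read by HPLC, at pH 7.4; on this read-out higher numbers stand for higher lipophilicity and lower numbers for lower lipophilicity

compound 1 `O=C(O)CNC(=O)COc1ccc([C@H]2CC[C@]3(CC2)OOC2(O3)C3CC4CC(C3)CC2C4)cc1`: 3
compound 2 `O=C(O)CN1CCC(Oc2ccc([C@H]3CC[C@]4(CC3)OOC3(O4)C4CC5CC(C4)CC3C5)cc2)CC1`: "not determined" (no result reported)
compound 3 `CS(=O)(=O)NC(=O)COc1ccc([C@H]2CC[C@]3(CC2)OOC2(O3)C3CC4CC(C3)CC2C4)cc1`: 3

In this assay compound 3 stands level with compound 1 at the digits shown, and compound 2 offers no number for comparison. Among the compounds with values here, the one measured step (no change at the digits printed from compound 1 to compound 3 (within the scatter)) is methylsulfonyl in place of carboxymethyl on an amide-type nitrogen.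

Compound 4 `O=C(O)c1ccc([C@H]2CC[C@]3(CC2)OOC2(O3)C3CC4CC(C3)CC2C4)cc1` differs from compound 3 by carboxy in place of ((methylsulfonyl)carbamoyl)methoxy on an aromatic carbon on an aromatic carbon of a six-membered aromatic ring of carbon only, para to a large group. The measured step bears on this only indirectly, since it alters the end of the chain while the change here removes the whole ((methylsulfonyl)carbamoyl)methoxy group. Within the data shown here, no measured step shows the size of that removal.

Among the measured compounds shown here, the expectation of a modest step rests on compound 1 and compound 3 sharing one reading (no change at the digits printed from compound 1 to compound 3 (within the scatter)), and the downward direction is a weak call that no measured step supports. The expected step is small (a number 0.40 log units lower from compound 3 to compound 4 (beyond the scatter)), and the range still includes no change. The estimated value for compound 4 is 2.6 with an expected range from 1.9 to 3.3 on this evidence.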

Compound 4, distribution coefficient: 3
Beside the measured number, compound 4's estimate is 0.40 log units below it; low and high end bracket the measured number.
By their numbers in this assay, from the lowest: compounds 1, 3 and 4 (each within the scatter of the next).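

In this assay the whole ((methylsulfonyl)carbamoyl)methoxy group gives way to carboxy on the aromatic carbon with no change at the digits printed from compound 3 to compound 4 (within the scatter), whereas the earlier measured step altered only the end of the chain. Replacing ((carboxymethyl)carbamoyl)methoxy with carboxy at the same place gives no change at the digits printed from compound 1 to compound 4 (within the scatter), so among these three groups the read-out at the digits printed does not separate the long chains from the single carboxy group. No evidence at hand explains this flat reading.

From the compounds shown here alone, whether this holds only for these three groups remains open, since every compound with a reading here carries a carboxy or (methylsulfonyl)carbamoyl end, and a primary amine, a methyl ester or a plain hydrogen on this aromatic carbon could read differently. A longer chain ending in a carboxylic acid, or a simple methoxy group with no acid-type end, would show whether the level seen here extends beyond these groups or is particular to them.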